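The compounds below may be only part of what the source reports. "The series", "measured", "known", "first", "only" and "open" are said of these compounds alone.

Of the compounds shown here, two built on the same core have been measured in a functional assay on DU-145 cells (Homo sapiens) for inhibition, read by sulforhodamine B assay, with a stated time of 48 h, tested at 10 uM; on this read-out lower numbers stand for a stronger effect and higher numbers for a weaker effect at the one concentration tested. Compound 1 `COc1cc(Cl)cc(-c2nn(-c3cccc(NC(=O)c4ccc(Cl)c(Cl)c4)c3)cc2-c2ccncc2)c1` carries an amide, and in this assay compound 1 gives 88.5%. Compound 2 `COc1cc(Cl)cc(-c2nn(-c3cccc(NC(=O)Nc4ccc(Cl)c(Cl)c4)c3)cc2-c2ccncc2)c1` carries a urea instead, and in this assay compound 2 gives 12.1%. The change from compound 1 to compound 2 is a number 76.4 percentage points lower from compound 1 to compound 2 (beyond the scatter), so compound 2 stands as the stronger of the two measured compounds, with compound 1 far above it.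

Compound 3 `COc1cc(Cl)cc(-c2nn(-c3cccc(NC(=O)Nc4cccc(C(F)(F)F)c4)c3)cc2-c2ccncc2)c1` keeps the urea of compound 2 and alters the aryl group on its far nitrogen: 3-(trifluoromethyl)phenyl in place of 3,4-dichlorophenyl on an amide-type nitrogen. Going by the values given here, the only measured step, from compound 1 to compound 2, concerns the urea itself and not the aryl group on it, so no measured step bears directly on this change. The urea-bearing compound 2 is the nearest point of reference. Compound 3 is therefore expected to stay on the stronger side, with a step of a number 17.9 percentage points higher from compound 2 to compound 3 (beyond the scatter) allowed for the uncertainty of an untested aryl exchange. The estimate for compound 3 is 30%, within a range from 8% to 70%.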

Compound 3, a percentage reported as activity, at one concentration (the size of the read-out at that concentration, not a potency): 15.9%
Compound 3: middle estimate off by 14.1 percentage points, on the high side; the measured number falls inside the stated range.
By their numbers in this assay, from the lowest: compounds 2 and 3 (each within the scatter of the next); then compound 1.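

With the urea kept, 3-(trifluoromethyl)phenyl in place of 3,4-dichlorophenyl on the amide-type nitrogen gives a number 3.8 percentage points higher from compound 2 to compound 3 (within the scatter) in this assay, so this read-out does not separate these two aryl groups at this position. The strong effect seen with the urea therefore does not depend on 3,4-dichlorophenyl alone: against the amide, exchanging the whole piece on the carbonyl carbon gives a number 72.6 percentage points lower from compound 1 to compound 3 (beyond the scatter), a large step of the same kind as a number 76.4 percentage points lower from compound 1 to compound 2 (beyond the scatter). No supporting information on why the two aryl groups behave alike is available here.

From the compounds shown here alone, both groups on this nitrogen are phenyl rings bearing chlorine or fluorine-containing substituents, so it remains open whether the effect holds with a plain phenyl, a phenyl bearing a carboxylic acid or an amine, or a simple alkyl chain in their place. Going by these compounds, it is also open whether an amide carrying 3-(trifluoromethyl)phenyl would stay as weak as compound 1, which would test the urea with the aryl group held constant on this second example.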